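The compounds below may be only part of what the source reports. "The series", "measured", "known", "first", "only" and "open" are said of these compounds alone.

Measured so far in a functional assay on A549 cells (Homo sapiens) for antiproliferative activity, read by resazurin assay, with a stated time of 48 h; on this read-out lower numbers stand for stronger inhibition of growth and higher numbers for weaker inhibition of growth:
Compound 1 (`CCC(CC)Nc1nc(Nc2cc(N3C[C@@H]4C[C@H]3CN4C)cnc2F)ncc1C`): > 10000 nM (a limit of the assay, not a number)
Compound 2 (`Cc1cnc(Nc2cc(N3C[C@@H]4C[C@H]3CN4C)cnc2F)nc1Nc1cccc(CO)c1`): 253 nM (the only number)

Going by the values given here, compound 2 therefore has the only true number in this assay to date. Compound 1 gives only a limit (the limit of > 10000 nM in this assay, at which 1 of the 2 values shown sits) and no number.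

Among the compounds with values here, compound 3 (`CC[C@@H](C)Nc1nc(Nc2cc(N3C[C@@H]4C[C@H]3CN4C)cnc2F)ncc1C`), not yet measured, has sec-butyl in place of 3-(hydroxymethyl)phenyl on a nitrogen on an aromatic ring as its one change from compound 2. Within the data shown here, the single measured step that bears on this runs the other way: an at least 39-fold lower number from compound 1 to compound 2 (1.59 log units; beyond the scatter) on going from pentan-3-yl to 3-(hydroxymethyl)phenyl. Sec-butyl, like pentan-3-yl, has no ring, so a large step back towards weaker inhibition of growth is expected, and compound 3 may well report only a limit. The estimated change is a 28-fold higher number from compound 2 to compound 3 (1.44 log units; beyond the scatter) in this assay overall. The estimate for compound 3 is 7000 nM with an expected range from 1500 nM to 15000 nM as its span.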

Compound 3, concentration for 50% growth inhibition: > 10000 nM
Compound 3: a limit, no number; the forecaster's own chance of this, stated with the estimate: 55%; middle value at least 1.4-fold (0.15 log units) away from the limit.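

In this assay, the large loss is now shown for a second open chain, not for pentan-3-yl alone: sec-butyl in place of 3-(hydroxymethyl)phenyl on a nitrogen on an aromatic ring gives an at least 39-fold higher number from compound 2 to compound 3 (1.59 log units; beyond the scatter). The step between compound 1 and compound 3 cannot be read, since each gives a limit and not a number. Neither of these two open-chain compounds yields a number, and both sit at the same limit: the limit of > 10000 nM in this assay, at which 2 of the 3 values shown sit.

The compounds shown leave open whether the aromatic ring or its hydroxymethyl group carries the difference, which an unsubstituted phenyl or a cyclohexyl on this nitrogen would help to separate. As far as these compounds go, how far the number of compound 2 can move with another ring substituent, such as an amine or a carboxylic acid, also remains open.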